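Trimming a Branched Chain on the Shared Core

A few compounds are considered here, and "the series" means these few. Any claim that something is new, unique, unknown or untested is made for them only; others in the source may bear on it.

Two compounds have numbers in a functional assay on PC-3 cells (Homo sapiens) for antiproliferative activity, read by MTT assay, with a stated time of 48 h; a higher number here means a weaker inhibitor of growth, a lower number a stronger inhibitor of growth. Compound 2 `Cc1ccc(-c2cnc(N(Cc3ccc(C(=O)NO)cc3)CC(C)C)s2)cc1` gives 9340 nM, the larger of the two, while compound 1 `CCCCN(Cc1ccc(C(=O)NO)cc1)c1ncc(-c2ccc(C)cc2)s1` gives 6410 nM; the step of a 1.5-fold higher number from compound 1 to compound 2 (0.16 log units; within the scatter) stays within the scatter, so the two cannot be told apart. Compound 3 `CCCN(Cc1ccc(C(=O)NO)cc1)c1ncc(-c2ccc(C)cc2)s1` is not yet measured and differs from compound 2 by hydrogen in place of methyl on a saturated chain carbon bound to two saturated chain carbons. Among the compounds with values here, the only step in hand reshaped this same chain without moving the number beyond the scatter, so the expected step of a 1.2-fold lower number from compound 2 to compound 3 (0.10 log units; within the scatter) is likewise none beyond the scatter. Compound 3 is therefore estimated at 7500 nM in this assay, between 3500 nM and 16000 nM.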

Compound 3, concentration for 50% growth inhibition: 9160 nM
Estimate against measurement, compound 3: 1.2-fold (0.09 log units) below, within the range that was stated.
By their numbers in this assay, from the lowest: compounds 1, 3 and 2 (each within the scatter of the next).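

In this assay, the step of a 1.0-fold lower number from compound 2 to compound 3 (0.01 log units; within the scatter) comes from hydrogen in place of methyl on a saturated chain carbon bound to two saturated chain carbons. The same swap three bonds along the chain from a nitrogen on an aromatic ring gives a 1.4-fold higher number from compound 1 to compound 3 (0.16 log units; within the scatter) and so also leaves the number within the scatter. Across these compounds, then, this chain has tolerated both changes, and nothing measured here explains that result. As far as these compounds go, whether a longer chain, an amine or a carboxylic acid in place of this chain would move the number stays open.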